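A few compounds are considered here, and "the series" means these few. Any claim that something is new, unique, unknown or untested is made for them only; others in the source may bear on it.

Compound 1 `O=[N+]([O-])c1cccc(Cn2cc(COc3ccccc3)nn2)c1` gives 25.3 ug/mL in a physicochemical assay, read by spectrophotometry, with a stated time of 30 min; a higher number here means a weaker inhibitor, a lower number a stronger inhibitor. Compound 2 `Clc1cccc(Cn2cc(COc3ccccc3)nn2)c1` gives 27.3 ug/mL in this assay. Compound 3 `Cc1cc(OCc2cn(Cc3ccc([N+](=O)[O-])cc3)nn2)ccc1Cl` gives 13.4 ug/mL in this assay.

Among the measured compounds shown here, compound 1 and compound 2 share one core, and the single change between them is chloro in place of nitro on an aromatic carbon. That change made a 1.1-fold higher number from compound 1 to compound 2 (0.03 log units; within the scatter), so the two values are indistinguishable. Compound 3 has a different core; how it differs from the core of compound 1 is not broken down here. Compound 4 `Cc1cc(OCc2cn(Cc3ccc(Cl)cc3)nn2)ccc1Cl` has not yet been measured. It differs from compound 3 by chloro in place of nitro on an aromatic carbon, the same kind of change as from compound 1 to compound 2, though the surroundings differ: in the measured pair the group sits meta to a large group, whereas in compound 4 it sits para to a large group. Since the measured example of this change barely moved the number, the corresponding step is expected to be small as well, a 1.1-fold higher number from compound 3 to compound 4 (0.05 log units; within the scatter), because a 1.1-fold higher number from compound 1 to compound 2 (0.03 log units; within the scatter) lay within the scatter. Compound 4 is therefore estimated at 15 ug/mL, with a likely range from 7 ug/mL to 30 ug/mL.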

Compound 4, half-maximal inhibitory concentration: 11.4 ug/mL
The estimate for compound 4 lay 1.3-fold (0.12 log units) above the measured number; the measured number falls inside the stated range.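

Chloro in place of nitro gave a 1.2-fold lower number from compound 3 to compound 4 (0.07 log units; within the scatter) in this assay and had given a 1.1-fold higher number from compound 1 to compound 2 (0.03 log units; within the scatter) on the other core, so in both pairs the change cannot be told apart from no change at all. The quiet result therefore carried over from one core to another, including to compound 4, where the chloro sits para to a large group, yet two pairs are too few to promise the same on any further core, and the words "higher" and "lower" in these two steps mark no real difference in direction. Nothing measured here explains why the swap moves the number so little.

The compounds shown leave open whether a different group at this place on the ring, such as an amine or a carboxylic acid, would shift the number beyond the scatter. Also open, on these data alone, is whether the swap stays this small in any other kind of test.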